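A few compounds are considered here, and "the series" means these few. Any claim that something is new, unique, unknown or untested is made for them only; others in the source may bear on it.

Compound 1, `COc1ccc(-c2cc(/C=C/C(=O)c3ccc(N)cc3)[nH]n2)cc1`: 94%
Compound 2, `COc1ccc(-c2cc(/C=C/C(=O)c3ccc(N)cc3)[nH]n2)cc1OC`: 99%
Compound 3, `COc1cc(C(=O)/C=C/c2cc(-c3cc(OC)c(OC)c(OC)c3)n[nH]2)cc(OC)c1OC`: 98%

These three compounds were tested in a functional assay on SN12C cells (Homo sapiens) for cytotoxicity, read by sulforhodamine B assay, with a stated time of 48 h, tested at 0.1 uM; a higher number here means a weaker effect of the compound at the concentration tested, a lower number a stronger effect. Compound 1 gives 94%, compound 2 gives 99%, and compound 3 gives 98%; all three numbers lie close together and none of them differs from another by more than the usual scatter. Compound 2 and compound 1 differ in one place, (hydrogen in place of methoxy on an aromatic carbon), and the step of a number 5 percentage points lower from compound 2 to compound 1 (within the scatter) is small. How the core of compound 3 differs from the core of compound 2 is not broken down here.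

Compound 4, `COc1ccc(-c2cc(/C=C/C(=O)c3cc(OC)c(OC)c(OC)c3)[nH]n2)cc1OC`, has not been measured. It differs from compound 3 in one place, (hydrogen in place of methoxy on an aromatic carbon). Within the data shown here, this is the same kind of change as the one from compound 2 to compound 1, though not the same: around the place in compound 3 the hydrogen also enters meta to a methoxy group, which is not said of the place in compound 2. In this assay compound 4 is therefore expected to show a step of about a number 3 percentage points lower from compound 3 to compound 4 (within the scatter) from compound 3, an expectation resting on the small step of a number 5 percentage points lower from compound 2 to compound 1 (within the scatter) seen for the earlier pair. For compound 4 the estimate is 95%, with a range from 84% to 104% expected to hold most repeat measurements.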

Compound 4, a percentage reported as activity, at one concentration (the size of the read-out at that concentration, not a potency): 99%
Compound 4: the middle estimate sits 4 percentage points below what was measured, and the stated range covers the measured number.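

In this assay, hydrogen in place of methoxy on an aromatic carbon can now be read on two cores, and the new pair shows a number 1 percentage points higher from compound 3 to compound 4 (within the scatter). Set beside the earlier pair, the two steps do not differ, so within these two cores the change carries over without any difference that stands out from the scatter: the same change on two cores in this assay, a number 5 percentage points lower (within the scatter) from compound 2 to compound 1 and a number 1 percentage points higher (within the scatter) from compound 3 to compound 4, 6 percentage points apart, within the scatter of two such steps

This agreement does not show that the change has a shared effect that can be transferred, since neither step rises above the scatter, and at the single concentration tested a common small effect cannot be told apart from no effect at all; two cores also say nothing about how the change would behave on any other core in the series.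

The compounds shown leave open what a hydroxy group, a fluorine atom or a longer alkoxy chain would give in this assay at the places where methoxy and hydrogen were compared here. They also leave open whether the two pairs would separate at a higher concentration, where the read-out might move away from the narrow band in which all four compounds lie.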